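Notes on the step from compound 2 to compound 4

A few compounds are considered here, and "the series" means these few. Any claim that something is new, unique, unknown or untested is made for them only; others in the source may bear on it.

In a functional assay on K562 cells (Homo sapiens) for cytotoxicity, read by MTT assay, with a stated time of 3 days (on this read-out higher numbers stand for weaker inhibition and lower numbers for stronger inhibition), compound 1 `N#Cc1c(Cl)nc(SCc2nc3ccccc3[nH]2)nc1-c1ccccc1` gives 11.3 nM, compound 2 `N#Cc1c(NN)nc(SCc2nc3ccccc3[nH]2)nc1-c1ccccc1` gives 14.7 nM and compound 3 `N#Cc1c(NNC(N)=S)nc(SCc2nc3ccccc3[nH]2)nc1-c1ccccc1` gives 8.9 nM. Compound 2 stands within the scatter of both other compounds: a 1.3-fold higher number from compound 1 to compound 2 (0.11 log units; within the scatter) and a 1.7-fold lower number from compound 2 to compound 3 (0.22 log units; within the scatter).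

Compound 4 `N#Cc1c(NC(N)=S)nc(SCc2nc3ccccc3[nH]2)nc1-c1ccccc1` is still unmeasured. It differs from compound 2 by a group of 3 heavy atoms (1 carbon, 1 nitrogen, 1 sulfur; no ring) in place of one nitrogen atom, on a nitrogen on an aromatic ring: the amino group leaves, and a group of 3 heavy atoms enters on a nitrogen on an aromatic ring.

The closest evidence is the step that adds a group of the same count to compound 2, a 1.7-fold lower number from compound 2 to compound 3 (0.22 log units; within the scatter). Also relevant is a 1.3-fold lower number from compound 1 to compound 3 (0.10 log units; within the scatter), where a larger group replaces chlorine. Among the measured compounds shown here, neither step exceeds the scatter, though three compounds give only a narrow basis, and compound 4 itself has no direct precedent.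

No change beyond the scatter is therefore expected in this assay, and the estimated step is a 1.3-fold lower number from compound 2 to compound 4 (0.13 log units; within the scatter). For compound 4 the expected value is 11 nM, with an estimated range of 5 nM to 25 nM.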

Compound 4, half-maximal inhibitory concentration: 11.9 nM
Compound 4: middle estimate off by 1.1-fold (0.03 log units), on the low side, and the stated range covers the measured number.
By their numbers in this assay, from the lowest: compounds 3, 1, 4 and 2 (each within the scatter of the next).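

In this assay the group of 3 heavy atoms on a nitrogen on an aromatic ring leaves the read-out flat, both against the amino group (a 1.2-fold lower number from compound 2 to compound 4 (0.09 log units; within the scatter)) and against the other group listed at this place (a 1.3-fold higher number from compound 3 to compound 4 (0.13 log units; within the scatter)). The same holds against chlorine on the aromatic carbon (a 1.1-fold higher number from compound 1 to compound 4 (0.02 log units; within the scatter)), so all four compounds now lie within the scatter of one another, and varying the size of this group among the listed compounds has not moved the number beyond it. Nothing measured in this series offers an explanation for how closely these values agree.

From the compounds shown here alone, whether a carboxylic acid, a morpholine ring or a longer alkyl chain at this place would move the number beyond the scatter stays open. Going by these compounds, how changes elsewhere on the shared core would read also stays open.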